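Swapping the terminal amine on the shared core

A few compounds are considered here, and "the series" means these few. Any claim that something is new, unique, unknown or untested is made for them only; others in the source may bear on it.

compound 1 `NCCN1C(=O)NC2(CSC3=C2C(=O)c2ccccc2C3=O)C1=O` gives 35 nM; 34 nM; 47 nM (3 entries)
compound 2 `NCCCCN1C(=O)NC2(CSC3=C2C(=O)c2ccccc2C3=O)C1=O` gives 68 nM

These values come from a functional assay on SW-620 cells (Homo sapiens) for inhibition (a lower number here means a stronger inhibitor, a higher number a weaker inhibitor), and those of compound 1 and compound 2 lie within the usual scatter of each other. Compound 2 stands on a single number, 68 nM, and one further entry for it gives no single number.

Compound 3 `CN(C)CCN1C(=O)NC2(CSC3=C2C(=O)c2ccccc2C3=O)C1=O` has the same atoms as compound 2, joined differently: dimethylamino in place of 2-aminoethyl on a saturated chain carbon, two bonds along the chain from an amide-type nitrogen in a ring. The same difference reads as 4-aminobutyl to 2-(dimethylamino)ethyl. Among the compounds with values here, no measured step covers this change. The side chains of compound 1 at 35 nM; 34 nM; 47 nM (3 entries) and compound 2 at 68 nM differ, yet their values stay within the scatter, so no shift beyond it is expected in this assay, in either direction. The expected step of a 1.1-fold lower number from compound 2 to compound 3 (0.05 log units; within the scatter) is therefore small. Compound 3 is estimated at 60 nM, with an expected range from 20 nM to 180 nM.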

Compound 3, half-maximal inhibitory concentration: 57 nM
Beside the measured number, compound 3's estimate is 1.1-fold (0.02 log units) above it; measured number inside the range.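

Dimethylamino in place of 2-aminoethyl on a saturated chain carbon, two bonds along the chain from an amide-type nitrogen in a ring, gives a 1.2-fold lower number from compound 2 to compound 3 (0.08 log units; within the scatter) in this assay. Compounds 1 and 2 both end in a primary amine, whereas this change brings in a group with 0 hydrogen-bond donors against 1 for 2-aminoethyl, and the read-out stays within the scatter, so for this pair a donor on the terminal amine makes no measurable difference. The step is also no larger than the spread among repeat entries of a single compound: the several entries of compound 1 in this assay, 35 nM; 34 nM; 47 nM (3 entries)

Whether the side chain needs any amine at all remains open, since a chain ending in a hydroxyl or a carboxylic acid does not appear among these compounds. Also open, from the compounds shown here alone, is how a morpholine at the chain end, or dimethylamino on a longer chain, would read.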